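The source may hold more compounds than are shown below. What is called first, only, known or untested is meant among the compounds shown, and "the series" means these compounds.

Working notes on the series. Compound 1 `CCCCCCCCCCCCCCCCCC/N=c1\nc(N)c2nc[nH]c2c(N)n1` carries the octadecyl chain on the double-bonded nitrogen and an unsubstituted ring nitrogen. Among the measured compounds shown here, in a functional assay on MCF7 cells (Homo sapiens) for antiproliferative activity, read by WST assay, with a stated time of 72 h (a higher number here means a weaker inhibitor, a lower number a stronger inhibitor), compound 1 gives 3530 nM, the second highest of the three numbers so far. Its nearest neighbour is compound 2 `CCCCCCCCCCCCCCCCCC/N=c1\nc(N)c2ncn(Cc3ccccc3)c2c(N)n1`, which in this assay gives 8300 nM; the step of a 2.4-fold higher number from compound 1 to compound 2 (0.37 log units; beyond the scatter) comes with benzyl in place of hydrogen on an aromatic nitrogen. Furthest from it is compound 3 `CCCCCCCCCC/N=c1\nc(N)c2ncn(Cc3ccccc3)c2c(N)n1`, which in this assay gives 1400 nM; this value and that of compound 1 differ in chain and ring substituent at once, so no single-change step joins them.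

Compound 4 `CCCCCCCC/N=c1\nc(N)c2nc[nH]c2c(N)n1` differs from compound 1 by hydrogen in place of decyl on a saturated chain carbon, eight bonds along the chain from a double-bonded nitrogen. For the measured compounds named here, the one measured step that bears on this is a 5.9-fold lower number from compound 2 to compound 3 (0.77 log units; beyond the scatter), a shortening of the same chain on the benzyl-bearing core. Nothing measured shows whether the unsubstituted ring nitrogen alters that response, and the chain in compound 4 is shortened somewhat further than in compound 3, so the size is uncertain. A lower number in this assay is therefore expected for compound 4, of roughly that size, a 5.0-fold lower number from compound 1 to compound 4 (0.70 log units; beyond the scatter). Compound 4 is estimated at 700 nM, with a range from 250 nM to 2500 nM.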

Compound 4, half-maximal inhibitory concentration: "not active" (no number reported)
Nothing numeric was reported for compound 4, and the estimate cannot be compared.
By their numbers in this assay, from the lowest: compound 3; then compound 1; then compound 2.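

Among the compounds shown here, compound 4 is reported in this assay as "not active", without a number, so no step from compound 1 to compound 4 can be read. The compounds shown leave open how the decyl-to-hydrogen change acts on the core of compound 1, and whether it tracks the chain shortening from compound 2 to compound 3. No supporting evidence bears on this result.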